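A few compounds are considered here, and "the series" means these few. Any claim that something is new, unique, unknown or untested is made for them only; others in the source may bear on it.

Measured so far in a functional assay on SW-620 cells (Homo sapiens) for inhibition, read by MTT assay, with a stated time of 48 h; a higher number here means a weaker inhibitor, a lower number a stronger inhibitor:
compound 1 `Cc1ccc(NC(=S)NC(=O)c2ccc(OCc3ccc(F)cc3)cc2)cc1-c1nc2ccccc2[nH]1` gives 40500 nM;
compound 2 `Cc1ccc(NC(=O)NC(=O)c2ccc(OCc3ccccc3)cc2)cc1-c1nc2ccccc2[nH]1` gives 30100 nM;
compound 3 `Cc1ccc(NC(=O)NC(=O)c2ccc(OCc3cccc(C(F)(F)F)c3)cc2)cc1-c1nc2ccccc2[nH]1` gives 9640 nM.

Compound 3 has the lowest number of the three and is thus the strongest inhibitor of the set; compound 2 sits nearest to it and compound 1 furthest, and both gaps lie beyond the scatter. Compound 4 `Cc1ccc(NC(=O)NC(=O)c2ccc(OCc3cccc(Cl)c3Cl)cc2)cc1-c1nc2ccccc2[nH]1` has not yet been measured. It differs from compound 3 in one place: 2,3-dichlorophenyl in place of 3-(trifluoromethyl)phenyl on a saturated chain carbon bound to an oxygen on an aromatic ring. Among the measured compounds shown here, only one measured step touches this part of the molecule: a 3.1-fold lower number from compound 2 to compound 3 (0.49 log units; beyond the scatter), a modest gain from placing a trifluoromethyl group onto the benzyl group that carried no substituent in compound 2. For the measured compounds named here, no measured pair shows what chlorine does in place of trifluoromethyl, so the direction of the new step cannot be read from the data; what can be said is that both compound 3 and compound 4 carry a substituted benzyl group rather than a bare one, and the substituted one was the better of the measured pair. Compound 4 is therefore expected to land close to compound 3, with the step of a 1.1-fold lower number from compound 3 to compound 4 (0.05 log units; within the scatter) estimated to stay within the scatter. The estimate for compound 4 in this assay is 8500 nM, with a range from 3000 nM to 25000 nM.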

Compound 4, half-maximal inhibitory concentration: 42100 nM
Estimate against measurement, compound 4: 5.0-fold (0.69 log units) below; measured number outside the range, above it.
By their numbers in this assay, from the lowest: compound 3; then compounds 2, 1 and 4 (each within the scatter of the next).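

In this assay, the result shows that substitution on this benzyl ring does not help as a general rule: the earlier gain of a 3.1-fold lower number from compound 2 to compound 3 (0.49 log units; beyond the scatter) does not carry over to every substituted ring, since replacing 3-(trifluoromethyl)phenyl with 2,3-dichlorophenyl gives a 4.4-fold higher number from compound 3 to compound 4 (0.64 log units; beyond the scatter) as its step. Measured against the bare phenyl ring, the same 2,3-dichlorophenyl group gives a 1.4-fold higher number from compound 2 to compound 4 (0.15 log units; within the scatter) and so stays within the scatter, which means that among these three compounds only the 3-(trifluoromethyl)phenyl group stands apart. Nothing available on these compounds accounts for the gap between the two substituted rings.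

Compound 3 and compound 4 differ both in the kind of substituent and in how the substituents are arranged on the ring, so the compounds shown cannot separate these two influences. They also leave open whether a single chlorine on this ring would behave like the two chlorines of compound 4, and how a methoxy group or a nitrile there would compare with trifluoromethyl.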